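Working notes: ethylsulfanyl to (4-methoxybenzyl)sulfanyl

The source may report more compounds than this note shows. Statements on the series, on what has been measured and on what is new or still open speak of the compounds shown alone.

Measured so far in a functional assay on PC-3 cells (Homo sapiens) for inhibition, read by MTT assay, with a stated time of 48 h (on this read-out lower numbers stand for stronger inhibition and higher numbers for weaker inhibition), as follows
- compound 1 `COc1ccc(CSc2nnc(-c3cc(OC)c(OC)c(OC)c3)n2-c2ccc(OC)cc2)cc1` gives 40300 nM
- compound 2 `CCSc1nnc(-c2cc(OC)c(OC)c(OC)c2)n1-c1ccc(N(C)C)cc1` gives 46200 nM

Compound 2 at 46200 nM stands level with compound 1 at 40300 nM within the usual scatter, so these two values set no order. Within the data shown here, no pair of measured compounds differs in one place only, so no measured step shows what a change at a single place does.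

Compound 3 `COc1ccc(CSc2nnc(-c3cc(OC)c(OC)c(OC)c3)n2-c2ccc(N(C)C)cc2)cc1` is not yet measured and departs from compound 2 in one place 4-methoxyphenyl in place of methyl on a saturated chain carbon bound to a sulfur with 4-methoxyphenyl in place of methyl on a saturated chain carbon bound to a sulfur. Compound 1 also carries a (4-methoxybenzyl)sulfanyl and gives 40300 nM so only a small step toward a lower number is expected in this assay and probably none beyond the scatter. The estimated change is a 1.5-fold lower number from compound 2 to compound 3 (0.19 log units; within the scatter) as a working figure. For compound 3 the expected value is 30000 nM with an estimated range of 9000 nM to 70000 nM on present data.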

Compound 3, half-maximal inhibitory concentration: > 60000 nM
Compound 3 gave a limit, no number (the forecaster's own chance of this, stated with the estimate: 10%); at least 2.0-fold (0.30 log units) between middle value and limit.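

Compound 3 gives only a limit in this assay, > 60000 nM, and not a number, so the steps that reach it have a floor but no size: the limit of > 60000 nM in this assay, at which 1 of the 3 values shown sits.

Among these compounds, these are the first single-place readings, and the change from ethylsulfanyl to (4-methoxybenzyl)sulfanyl gives an at least 1.2-fold higher number from compound 2 to compound 3 (0.11 log units; that floor lies within the scatter), while dimethylamino in place of methoxy on an aromatic carbon gives an at least 1.4-fold higher number from compound 1 to compound 3 (0.17 log units; that floor lies within the scatter). Neither floor clears the scatter, so neither change can yet be called a real loss, but neither the larger group on the sulfur nor the dimethylamino group brings a lower number in this set.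

On these data alone, the true size of both steps stays open, as does whether either change alone matters once compound 3 has a number rather than a limit. Also open, as far as these compounds go, is what other groups on the sulfur would give in this assay, such as a longer chain like butyl, or a chain ending in an amine or a carboxylic acid.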